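Piperidin-1-yl for Diisopropylamino on Two Different Cores

This account rests on a few compounds, and the source may have more. Where it says the series, first, only, none or still open, it means among the compounds named here.

Compound 1 `COc1ccc(/C=C/c2nc(NCCN(C(C)C)C(C)C)c3cc(Cl)ccc3n2)cc1OC` and compound 2 `COc1ccc(/C=C/c2nc(NCCN3CCCCC3)c3cc(Cl)ccc3n2)cc1OC` share one core and differ in a single place: piperidin-1-yl in place of diisopropylamino on a saturated chain carbon, two bonds along the chain from a nitrogen on an aromatic ring. In a functional assay on DU-145 cells (Homo sapiens) for cytotoxicity, read by MTT assay, with stated times of 48 h and 4 h (on this read-out lower numbers stand for stronger inhibition and higher numbers for weaker inhibition), compound 1 reaches only a limit of the measurement, > 100000 nM. In this assay compound 2 gives 17200 nM. The step of an at least 5.8-fold lower number from compound 1 to compound 2 (0.76 log units; beyond the scatter) thus favours the piperidin-1-yl partner on this core.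

Compound 3 `CC(C)N(CCNc1nc(/C=C/c2ccc([N+](=O)[O-])cc2)nc2ccccc12)C(C)C` carries the diisopropylamino group on another core; the difference between the core of compound 1 and the core of compound 3 is not broken down here. In this assay compound 3 also sits at a limit, > 100000 nM. Two of the three values shown stand at that limit (the limit of > 100000 nM in this assay, at which 2 of the 3 values shown sit).

Compound 4 `O=[N+]([O-])c1ccc(/C=C/c2nc(NCCN3CCCCC3)c3ccccc3n2)cc1` is the untested counterpart of compound 3, reached by the same change: piperidin-1-yl in place of diisopropylamino on a saturated chain carbon, two bonds along the chain from a nitrogen on an aromatic ring. Compound 4 is expected to land near 30000 nM, within a range from 8000 nM to 120000 nM. The estimated step of an at least 3.3-fold lower number from compound 3 to compound 4 (0.52 log units; beyond the scatter) rests on the measured step of an at least 5.8-fold lower number from compound 1 to compound 2 (0.76 log units; beyond the scatter) on the first core, although a limit as starting point leaves the true size of the step open.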

Compound 4, half-maximal inhibitory concentration: > 100000 nM
Compound 4 ended at the assay's limit; the forecaster's own chance of this, stated with the estimate: 40%; at least 3.3-fold (0.52 log units) between middle value and limit.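

In this assay compound 4 stops at a limit of the measurement, > 100000 nM. Compound 3 stands at a limit as well, so no step can be read from compound 3 to compound 4. The compounds shown leave open whether piperidin-1-yl in place of diisopropylamino changes the read-out on the core of compound 3 at all, and most values shown stand at one limit: the limit of > 100000 nM in this assay, at which 3 of the 4 values shown sit.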